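The source may report more compounds than this note shows. Statements on the series, on what has been measured and on what is new or still open speak of the compounds shown alone.

Measured so far:
Compound 1, `CC(C)n1nc(-c2ccnc3[nH]c(C4CCN(CC(=O)N(C)C)CC4)cc23)ccc1=O`: 2
Compound 2, `CC(C)n1cc(-c2ccnc3[nH]c(C4CCN(CC(=O)N5CCCCC5)CC4)cc23)ccc1=O`: 2.8

Of the compounds shown here, two have been measured in a physicochemical assay for lipophilicity, using the shake flask method, measured as octanol-water partition, at pH 7.4; a higher number here means a more lipophilic compound, a lower number a more polar compound. Compound 1 gives 2, the lower of the two numbers. For the measured compounds named here, compound 2 differs from compound 1 in more than one place, so no single step connects them; in this assay compound 2 gives 2.8, a reading that stands beyond the scatter above that of compound 1, and that is all the pair can show.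

The compound now in question is compound 3, `CC(C)n1cc(-c2ccnc3[nH]c(C4CCN(CC(=O)N(C)C)CC4)cc23)cnc1=O`. It differs from compound 1 in one place: a group of 10 heavy atoms (7 carbon, 2 nitrogen, 1 oxygen; one six-membered aromatic ring with 2 hetero atoms) in place of a group of 10 heavy atoms (7 carbon, 2 nitrogen, 1 oxygen; one six-membered aromatic ring with 2 hetero atoms), on an aromatic carbon The two groups hold the same atoms joined differently, so the change is a rearrangement of the ring rather than an addition or removal of atoms. Going by the values given here, no measured pair shows what such a rearrangement does in this assay.

In this assay the step is expected to be small, a number 0.20 log units higher from compound 1 to compound 3 (within the scatter), at most a slight rise and quite possibly within the scatter. Compound 3 is therefore estimated at 2.2, with a range from 1.7 to 2.7.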

Compound 3, distribution coefficient: 0.4
For compound 3 the middle estimate is 1.80 log units above the measured one; the measured number lies below the stated range.
By their numbers in this assay, from the lowest: compound 3; then compound 1; then compound 2.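

With the same atoms present and only their arrangement changed, this assay records a number 1.60 log units lower from compound 1 to compound 3 (beyond the scatter), which is a large step. Compound 1 and compound 2 differ in more than one place, so they could not show what a single change does; this pair shows that, on this aromatic carbon opposite the ring nitrogen, rearranging the ring can alone move the reading far beyond the scatter, even though the two groups match in every count listed for them, including hydrogen-bond donors, hydrogen-bond acceptors and net charge. Nothing available here explains why the two arrangements read so differently.

For the compounds shown here, this is a single pair with one amide, so it remains open whether the same rearrangement would give a step of similar size on a compound with a different amide, such as the one in compound 2. On these data alone, it is also open how this assay would respond to a further group on the rearranged ring, such as a methyl, a methoxy or a chlorine atom, and whether any such group would raise the reading again.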